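From 4-fluoro-3-nitrophenyl to 4-bromophenyl on compound 1

The compounds below may be only part of what the source reports. "The series", "measured", "known", "first", "only" and "open" are said of these compounds alone.

Within the data shown here, in a functional assay on DU-145 cells (Homo sapiens) for inhibition, read by trypan blue exclusion, with a stated time of 96 h (a higher number here means a weaker inhibitor of growth, a lower number a stronger inhibitor of growth), compound 1 `O=C(/C(=C\c1ccc(F)c([N+](=O)[O-])c1)S(=O)(=O)c1ccc(Br)cc1)c1ccc(Br)cc1` gives 25000 nM and holds the higher of the two numbers measured so far. Compound 2 `COc1ccccc1/C=C(\C(=O)c1ccc(Cl)cc1)S(=O)(=O)Cc1ccc(Cl)c(Cl)c1` reads 1000 nM in this assay but differs from compound 1 in several places, so it offers no clean comparison. Among the measured compounds shown here, compound 3 `O=C(/C(=C\c1ccc(Br)cc1)S(=O)(=O)c1ccc(Br)cc1)c1ccc(Br)cc1` keeps the core of compound 1 and changes one group: 4-bromophenyl in place of 4-fluoro-3-nitrophenyl on a double-bonded chain carbon bound to a double-bonded chain carbon and no measured pair shows this change alone. What is expected in this assay is a modest shift toward stronger growth inhibition, estimated as a 2.5-fold lower number from compound 1 to compound 3 (0.40 log units; beyond the scatter) and perhaps little beyond the scatter. The estimate for compound 3 is 10000 nM with 2500 nM to 40000 nM as its expected range.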

Compound 3, concentration for 50% growth inhibition: 10000 nM
Compound 3: the middle estimate sits on the measured number at the digits printed; the range from low to high includes it.
By their numbers in this assay, from the lowest: compound 2; then compound 3; then compound 1.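

Placing 4-bromophenyl in place of 4-fluoro-3-nitrophenyl on a double-bonded chain carbon bound to a double-bonded chain carbon gives, in this assay, a 2.5-fold lower number from compound 1 to compound 3 (0.40 log units; beyond the scatter) and so provides the first clean reading of this position. With the rest of the core of compound 1 unchanged, the number responds to the group at this place, and 4-fluoro-3-nitrophenyl is not needed there for growth inhibition to be read. Nothing available explains the shift. The compounds shown do not separate the removal of the nitro group and the fluorine from the arrival of the bromine, as each change appears only within this single exchange. They also leave open how the number would move with an aminophenyl or a carboxyphenyl group at this place.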